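Removing a Chlorine from the Weakest of Three Analogues

A few compounds are considered here, and "the series" means these few. Any claim that something is new, unique, unknown or untested is made for them only; others in the source may bear on it.

Of the compounds shown here, three built on one shared core have been tested in a functional assay on NCI-H460 cells (Homo sapiens) for inhibition, read by MTT assay, with a stated time of 72 h; on this read-out lower numbers stand for stronger inhibition and higher numbers for weaker inhibition. Compound 1, `CCN(CC)CCCn1c(=O)c(=Cc2ccc(F)cc2F)s/c1=C1\C(=O)Nc2ccc(Cl)cc21`, gives 6100 nM. Compound 3, `CN(C)CCn1c(=O)c(=Cc2ccc(F)cc2F)s/c1=C1\C(=O)Nc2cc(F)ccc21`, gives 3200 nM, and compound 2, `CN(C)CCn1c(=O)c(=Cc2ccc(O)cc2)s/c1=C1\C(=O)Nc2ccc(F)cc21`, gives 1270 nM. Compound 1 has the highest of the three numbers. Its value and that of compound 3 lie within the usual scatter of each other, so the two cannot be told apart on these data, whereas the value of compound 2 lies beyond the scatter on the lower side. No two of the measured compounds differ from each other in just one place, so no single structural step can be read from them.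

Compound 4, `CCN(CC)CCCn1c(=O)c(=Cc2ccc(F)cc2F)s/c1=C1\C(=O)Nc2ccccc21`, has not yet been measured. Relative to compound 1 the change is hydrogen in place of chloro on an aromatic carbon. Among the measured compounds shown here, no measured pair shows what this change does on this core, and compounds 2 and 3 carry different chains and different aryl groups, so they offer no direct guide. The expectation is therefore a step of size a 1.1-fold higher number from compound 1 to compound 4 (0.06 log units; within the scatter), which is to say no change clearly beyond the scatter. On that basis compound 4 is estimated at 7000 nM, with an expected range from 3000 nM to 16000 nM.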

Compound 4, half-maximal inhibitory concentration: 5470 nM
Compound 4: middle estimate off by 1.3-fold (0.11 log units), on the high side; the measured number falls inside the stated range.
By their numbers in this assay, from the lowest: compound 2; then compounds 3, 4 and 1 (each within the scatter of the next).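

Among the compounds shown here, this is the first pair of compounds here that differ in only one place, so it gives the first direct reading of this position on the shared core: in this assay, hydrogen in place of chloro gives a 1.1-fold lower number from compound 1 to compound 4 (0.05 log units; within the scatter). Compound 1 and compound 4 therefore cannot be told apart, which means that on this core the level of inhibition seen in compound 1 does not depend on the chlorine, at least in this cell read-out. No separate measurement bears on this result, so the data offer no explanation for it.

As far as these compounds go, the pair compares only chloro and hydrogen on this aromatic carbon, so it remains open whether a larger or quite different group, such as methoxy, an amine or a carboxylic acid, would move the number beyond the scatter. From the compounds shown here alone, it also remains open whether the same swap would have so small an effect on a compound with a different chain or a different aryl group, since this single step comes from one background on the shared core.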